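The source may report more compounds than this note shows. Statements on the series, on what has been measured and on what is new or still open speak of the compounds shown alone.

Compound 1 `CCOC1=C(/C(C)=N/OCC(=O)Nc2ccc(C(F)(F)F)cc2)N(C)S(=O)(=O)c2ccccc21` is the only one of the three measured compounds that gives a number rather than a limit. In a functional assay on THP-1 cells (Homo sapiens) for inhibition, read by ELISA, with stated times of 2 h and 48 h (on this read-out higher numbers stand for weaker inhibition and lower numbers for stronger inhibition), compound 1 gives 16700 nM. Compound 2 `CCOC1=C(/C(C)=N/OCC(=O)Nc2ccc(F)c(Cl)c2)N(C)S(=O)(=O)c2ccccc21` differs from it by 3-chloro-4-fluorophenyl in place of 4-(trifluoromethyl)phenyl on an amide-type nitrogen. In this assay compound 2 gives > 20000 nM, which is a limit of the assay and not a number. That change gave an at least 1.1-fold higher number from compound 1 to compound 2 (0.07 log units; that floor lies within the scatter), a floor that arises because of the limit of > 20000 nM in this assay, at which 2 of the 3 values shown sit. Compound 3 `C/C(=N\OCC(=O)Nc1ccc(C(F)(F)F)cc1)C1=C(O)c2ccccc2S(=O)(=O)N1C` differs from compound 1 by hydrogen in place of ethyl on an oxygen on an unsaturated carbon. In this assay compound 3 gives > 20000 nM, again a limit. Compound 4 `C/C(=N\OCC(=O)Nc1ccc(F)c(Cl)c1)C1=C(O)c2ccccc2S(=O)(=O)N1C` differs from compound 3 by 3-chloro-4-fluorophenyl in place of 4-(trifluoromethyl)phenyl on an amide-type nitrogen, the same change, at the same place, as from compound 1 to compound 2. The expected step is a step that the limit leaves unreadable from compound 3 to compound 4, resting on compound 3 at > 20000 nM and on (the limit of > 20000 nM in this assay, at which 2 of the 3 values shown sit). Compound 4 is therefore estimated at 30000 nM.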

Compound 4, half-maximal inhibitory concentration: > 20000 nM
Compound 4 gave a limit, no number (the forecaster's own chance of this, stated with the estimate: 85%); the middle value lies beyond the limit too.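

Compound 2, compound 3 and compound 4 all sit at a limit rather than a number, so neither step into compound 4 can be read: the limit of > 20000 nM in this assay, at which 3 of the 4 values shown sit.

On these data alone, whether 3-chloro-4-fluorophenyl in place of 4-(trifluoromethyl)phenyl, or hydrogen in place of ethyl, truly changes inhibition stays open.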